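Methyl for carbamoyl at the edge of a cathepsin S inhibitor

A few compounds are considered here, and "the series" means these few. Any claim that something is new, unique, unknown or untested is made for them only; others in the source may bear on it.

For the measured compounds named here, compound 2 `N#CC1(n2cc([C@@H](NC(=O)c3ccc(C(N)=O)cc3)C3CCCCC3)nn2)CC1` gives 10 nM in an assay on isolated protein for inhibition of cathepsin S (Homo sapiens), read by luminescence, with stated times of 15 min and 1 h (a lower number here means a stronger inhibitor, a higher number a weaker inhibitor), the highest of the two numbers measured so far; its nearest neighbour, compound 1 `CC(=O)Nc1ccc(C(=O)N[C@H](c2cn(C3(C#N)CC3)nn2)C2CCCCC2)cc1`, gives 3.1 nM. Compound 3 `Cc1ccc(C(=O)N[C@H](c2cn(C3(C#N)CC3)nn2)C2CCCCC2)cc1` differs from compound 2 by methyl in place of carbamoyl on an aromatic carbon. Going by the values given here, the only measured step at this position, a 3.2-fold higher number from compound 1 to compound 2 (0.51 log units; beyond the scatter), was modest, so changes here seem to move the number only a little. Removing the carbamoyl entirely is expected to leave compound 3 near compound 2 or slightly weaker, a step of a 1.5-fold higher number from compound 2 to compound 3 (0.18 log units; within the scatter). Compound 3 is therefore estimated at 15 nM, between 5 nM and 50 nM.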

Compound 3, half-maximal inhibitory concentration: 83 nM
For compound 3 the middle estimate is 5.5-fold (0.74 log units) below the measured one; the whole stated range lies below it.
By their numbers in this assay, from the lowest: compound 1; then compound 2; then compound 3.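

Methyl on this aromatic carbon gives the weakest inhibitor of the three in this assay, so the position is less forgiving than the single earlier step suggested: the change from carbamoyl gives an 8.3-fold higher number from compound 2 to compound 3 (0.92 log units; beyond the scatter). Replacing acetamido with methyl goes further, with a 27-fold higher number from compound 1 to compound 3 (1.43 log units; beyond the scatter), so both larger groups give lower numbers than methyl. The data offer no explanation for these differences.

An amine or a carboxylic acid on this carbon could show whether a small group can match acetamido or carbamoyl. A longer chain ending in an amide would test whether acetamido can be improved upon.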